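Removing One Methoxy Group from Compound 3

The compounds below may be only part of what the source reports. "The series", "measured", "known", "first", "only" and "open" are said of these compounds alone.

Measured compounds:
compound 1 `c1cn(Cc2ccc(-c3ccoc3)cc2)cn1` 29%
compound 2 `Cc1cscc1-c1ccc(Cn2ccnc2)cc1` 27%
compound 3 `COc1ccc(-c2csc(Cn3ccnc3)c2)cc1OC` 14%

In an assay for inhibition of steroid 17-alpha-hydroxylase/17,20 lyase (Homo sapiens), using NADPH, tested at 2 uM (a lower number here means a weaker effect, a higher number a stronger effect of the compound at the concentration tested), compound 3 gives the lowest of the three numbers; compound 2 stands higher by a margin beyond the scatter, and compound 1 higher still. For the measured compounds named here, the only measured step, a number 2 percentage points lower from compound 1 to compound 2 (within the scatter), lies within the scatter and concerns a different part of the molecule. Compound 4 `COc1ccc(-c2csc(Cn3ccnc3)c2)cc1` differs from compound 3 by hydrogen in place of methoxy on an aromatic carbon. Going by the values given here, no measured step involves a methoxy group, so nothing here bears directly on this change. The expectation is therefore a step of a number 4 percentage points higher from compound 3 to compound 4 (within the scatter) that is not beyond the scatter. Compound 4 is estimated at 18%, with a range from 5% to 35%.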

Compound 4, a percentage reported as inhibition, at one concentration (the size of the read-out at that concentration, not a potency): 13%
Compound 4: middle estimate off by 5 percentage points, on the high side; the measured number falls inside the stated range.
By their numbers in this assay, from the lowest: compounds 4 and 3 (each within the scatter of the next); then compounds 2 and 1 (each within the scatter of the next).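

In this assay, for the compounds shown here, the exchange of methoxy for hydrogen on an aromatic carbon, ortho to a methoxy group and meta to a large group, gives a number 1 percentage points lower from compound 3 to compound 4 (within the scatter) as the first measured step at this position. On this core, then, the methoxy group at this place can be lost with no change beyond the scatter. Nothing available explains this result.

As far as these compounds go, what a hydroxyl, an amine or a longer chain such as ethoxy would do at this position stays open. So does the effect of losing the remaining methoxy group.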